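Swapping propargyl for benzyl on an inactive carbamate

A few compounds are considered here, and "the series" means these few. Any claim that something is new, unique, unknown or untested is made for them only; others in the source may bear on it.

Measured so far:
- compound 1 `O=C(Nc1ccccc1)OC1CCCN(Cc2ccccc2)C1`, giving > 100000 nM
- compound 2 `C#CCN1CCCC(OC(=O)Nc2ccc(C(C)C)cc2)C1`, giving > 100000 nM

In an assay on BTI-TN-5B1-4 cells for inhibition of Amine oxidase [flavin-containing] A (Homo sapiens), read by fluorescence and Amplex Red, using microsomes, with a stated time of 15 min (on this read-out higher numbers stand for weaker inhibition and lower numbers for stronger inhibition), compound 1 gives only > 100000 nM, which is a limit of the assay rather than a number. Compound 2 likewise gives only the limit > 100000 nM in this assay. Both measured values therefore sit at the limit of > 100000 nM in this assay, at which 2 of the 2 values shown sit, and compound 2 stands at that limit, with nothing to separate it from compound 1. Compound 3 `CC(C)c1ccc(NC(=O)OC2CCCN(Cc3ccccc3)C2)cc1` is not yet measured. It differs from compound 2 by phenyl in place of ethynyl on a saturated chain carbon bound to an amine nitrogen in a ring, the same change read one bond further out as propargyl to benzyl. Since compound 2 is at the limit, the step can only show in this assay if compound 3 comes into the measurable range; the values of compound 1 give no sign of that. Compound 3 is expected to stay at the limit, with an estimated 150000 nM, ranging from 30000 nM to 600000 nM. The step that the limit leaves unreadable from compound 2 to compound 3 is expected to be none beyond the scatter.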

Compound 3, half-maximal inhibitory concentration: > 100000 nM
Compound 3 was reported as a limit; the forecaster's own chance of this, stated with the estimate: 85%; the middle value is on the limit's open side.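

Compound 3 also gives only a limit, not a number, so the steps to it from compound 2 and from compound 1 cannot be read in this assay: the limit of > 100000 nM in this assay, at which 3 of the 3 values shown sit.

The compounds shown leave open whether any of these carbamates inhibits measurably, and how strongly.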